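A few compounds are considered here, and "the series" means these few. Any claim that something is new, unique, unknown or untested is made for them only; others in the source may bear on it.

In a functional assay on MGC-803 cells (Homo sapiens) for antiproliferative activity, read by MTT assay, with a stated time of 72 h (on this read-out lower numbers stand for stronger inhibition and higher numbers for weaker inhibition), compound 1 `CCCSc1nc(N/N=C/c2ccc(C)cc2)c2nnn(Cc3ccccc3)c2n1` reaches only the assay limit, giving > 64000 nM, so no number stands for it and it sits at the limit of > 64000 nM in this assay, at which 1 of the 2 values shown sits. Compound 2 `CCCSc1nc(N/N=C/c2cc(OC)c(OC)c(OC)c2)c2nnn(Cc3ccccc3)c2n1`, from the same core, gives 9410 nM in this assay. Compound 3 `CCCSc1nc(N/N=C/c2ccc([N+](=O)[O-])cc2)c2nnn(Cc3ccccc3)c2n1` differs from compound 1 by nitro in place of methyl on an aromatic carbon. For the measured compounds named here, with compound 1 known only as a limit, no measured step is available for this change, and the step from compound 1 to compound 3 is expected to be a gain of about an at least 2.5-fold lower number from compound 1 to compound 3 (0.40 log units; beyond the scatter), though it may stay within the scatter. Compound 3 is estimated at 25000 nM, between 6000 nM and 64000 nM.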

Compound 3, half-maximal inhibitory concentration: 10100 nM
Compound 3: the middle estimate sits 2.5-fold (0.39 log units) above what was measured; low and high end bracket the measured number.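

In this assay, nitro in place of methyl on an aromatic carbon, para to a large group, gives an at least 6.3-fold lower number from compound 1 to compound 3 (0.80 log units; beyond the scatter). This shows that the position responds to this change, with a step beyond the scatter. The step's full size stays unknown because compound 1 stands only at a limit: the limit of > 64000 nM in this assay, at which 1 of the 3 values shown sits.

The compounds shown leave open how an amine, a carboxylic acid or a chlorine atom would read at this position. They also leave open whether an ethyl group would stay near the methyl or the nitro result.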